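This account rests on a few compounds, and the source may have more. Where it says the series, first, only, none or still open, it means among the compounds named here.

Compound 1 `O=C(/C=C/c1ccc2c(c1)B(O)OC2)c1ccc(F)cc1` is the reference point of this small set. In a functional assay on SK-OV-3 cells (Homo sapiens) for cytotoxicity, read by MTT assay, with a stated time of 48 h (on this read-out lower numbers stand for stronger inhibition and higher numbers for weaker inhibition), compound 1 gives 1400 nM, the lowest of the three numbers recorded. Its two neighbours are compound 2 `O=C(/C=C/c1ccc2c(c1)B(O)OC2)c1ccc(OCc2ccccc2)cc1`, which gives 6000 nM, and compound 3 `O=C(/C=C/c1ccc2c(c1)B(O)OC2)c1ccc([N+](=O)[O-])cc1`, which gives 7900 nM.

The compound now under consideration is compound 4 `Cc1cccc(C(=O)/C=C/c2ccc3c(c2)B(O)OC3)c1`. Relative to compound 1 the change is 3-methylphenyl in place of 4-fluorophenyl on a carbonyl carbon, so the fluorine-bearing ring as a whole is exchanged for one carrying a methyl group.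

The measured steps that bear on this are the two departures from compound 1 on that same ring: a 4.3-fold higher number from compound 1 to compound 2 (0.63 log units; beyond the scatter) and a 5.6-fold higher number from compound 1 to compound 3 (0.75 log units; beyond the scatter). Both replacements of the fluoro group led to weaker inhibition in this assay, by modest but real amounts; between compounds 2 and 3 the difference, a 1.3-fold higher number from compound 2 to compound 3 (0.12 log units; within the scatter), is within the scatter. Among the compounds with values here, no step with a methyl group, or with the group moved on the ring, exists here, so the expectation rests only on the observation that every departure from the fluoro group so far has cost potency.

Compound 4 is therefore expected to show a modest loss, a 2.0-fold higher number from compound 1 to compound 4 (0.30 log units; within the scatter), an estimated 2800 nM with a likely range from 1000 nM to 8000 nM.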

Compound 4, half-maximal inhibitory concentration: 2900 nM
The estimate for compound 4 lay 1.0-fold (0.02 log units) below the measured number, within the range that was stated.
By their numbers in this assay, from the lowest: compound 1; then compound 4; then compounds 2 and 3 (each within the scatter of the next).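

With compound 4, a ring carrying only carbon enters on the carbonyl carbon, and the number still rises beyond the scatter, a 2.1-fold higher number from compound 1 to compound 4 (0.32 log units; beyond the scatter). This makes it the third departure from the 4-fluorophenyl of compound 1 to give weaker inhibition in this assay, and none of the compounds shown goes against that pattern, although the step itself is modest. The change swaps the substituent and alters its printed place in a single move, and no measurement offered here explains the loss.

Going by these compounds, what remains open is whether the step comes from the methyl group itself or from where it sits on the ring, since this one exchange cannot separate the two. Also open, on these data alone, is how an unsubstituted phenyl ring, or a phenyl ring carrying an amine or a carboxylic acid, would read in this assay against compound 1, and so whether anything on this ring can match or improve on the 4-fluorophenyl group.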